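The source may hold more compounds than are shown below. What is called first, only, known or untested is meant among the compounds shown, and "the series" means these compounds.

Measured so far:
Compound 1, `O=[N+]([O-])c1ccc2c(c1)CN(c1ncnc3c1nc1n3[C@@H]3O[C@H](CO1)[C@@H](O)[C@H]3O)CC2`, in an assay on isolated protein for binding affinity to Equilibrative nucleoside transporter 1 (Homo sapiens) (a lower number here means a stronger inhibitor, a higher number a weaker inhibitor), gives 331 nM.
Compound 2, `OC[C@H]1O[C@@H](n2cnc3c(OCc4ccccc4)ncnc32)[C@H](O)[C@@H]1O`, in this assay gives 2090 nM.

Of these two numbers, compound 2 carries the higher one, so it is the weaker inhibitor; compound 1 gives a lower number, and that gap lies beyond the scatter. The next compound, compound 3, `OC[C@H]1O[C@@H](n2cnc3c(CSc4ccc(F)cc4)ncnc32)[C@H](O)[C@@H]1O`, has not been measured. It differs from compound 2 in one place: ((4-fluorophenyl)sulfanyl)methyl in place of benzyloxy on an aromatic carbon. Going by the values given here, no measured pair shows this change, so the expectation rests on compound 2 alone. A moderate step toward a lower number, beyond the scatter, is expected, a 4.6-fold lower number from compound 2 to compound 3 (0.67 log units; beyond the scatter). Compound 3 is estimated at 450 nM, likely between 100 nM and 2000 nM.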

Compound 3, half-maximal inhibitory concentration: 158 nM
Compound 3: the middle estimate sits 2.8-fold (0.45 log units) above what was measured, within the range that was stated.
By their numbers in this assay, from the lowest: compound 3; then compound 1; then compound 2.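

In this assay, putting ((4-fluorophenyl)sulfanyl)methyl in place of benzyloxy on this aromatic carbon gives a 13-fold lower number from compound 2 to compound 3 (1.12 log units; beyond the scatter), so the group at this position can move the number a long way. This happens even though both groups carry one six-membered aromatic ring of carbon only and one hydrogen-bond acceptor. Nothing available here accounts for the step.

Going by these compounds, the sulfur and the fluorine entered together, and the oxygen left at the same time, so the share of each stays open. A (phenylsulfanyl)methyl group without the fluorine, or an amine in the linking chain, would help separate them.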